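The compounds below may be only part of what the source reports. "The series", "measured", "known", "first", "only" and "open" are said of these compounds alone.

In an ADME assay on liver for metabolic stability, with Liver microsome (Rattus norvegicus) as the target, using microsomes and NADPH, with a stated time of 30 min, tested at 0.5 uM (on this read-out higher numbers stand for fast clearance and lower numbers for slow clearance), compound 3 `O=C1NCCN1CCOc1nn(-c2ccccc2F)c2ccc(F)cc12` gives 1380 mL/min/kg, within the scatter of compound 1 `O=c1[nH]ccn1CCOc1nn(-c2ccccc2F)c2ccc(F)cc12` at 783 mL/min/kg, while compound 2 `CN1CCN(CCOc2nn(-c3ccccc3F)c3ccc(F)cc23)C1=O` at 7200 mL/min/kg is the clear high point of the three. The steps bear this out: a 1.8-fold higher number from compound 1 to compound 3 (0.25 log units; within the scatter) and a 5.2-fold lower number from compound 2 to compound 3 (0.72 log units; beyond the scatter).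

Next in the series is compound 4 `O=C1NCCN1CCOc1nn(-c2ccc(F)cc2F)c2ccc(F)cc12`, with the change (fluoro in place of hydrogen on an aromatic carbon), which reads as 2-fluorophenyl to 2,4-difluorophenyl. Among the compounds with values here, none of the measured steps touches this aromatic ring. a 9.2-fold higher number from compound 1 to compound 2 (0.96 log units; beyond the scatter) and the other two steps all concern the group on the saturated chain, so they show only how far the numbers can move, and the data hold no direct precedent for the new fluoro. No change beyond the scatter is therefore expected, with only a slight lean towards a lower number. The expected step is a 1.3-fold lower number from compound 3 to compound 4 (0.10 log units; within the scatter). For compound 4 the estimated clearance is 1100 mL/min/kg, with an expected range of 500 mL/min/kg to 2400 mL/min/kg.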

Compound 4, clearance: 617 mL/min/kg
Compound 4: middle estimate off by 1.8-fold (0.25 log units), on the high side; low and high end bracket the measured number.
By their numbers in this assay, from the lowest: compounds 4, 1 and 3 (each within the scatter of the next, the first and the last beyond it); then compound 2.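

In this assay fluoro in place of hydrogen on an aromatic carbon, para to a large group and meta to a fluoro group, gives a 2.2-fold lower number from compound 3 to compound 4 (0.35 log units; beyond the scatter) and so goes beyond the scatter. Within the data shown here, this is the first measured step on this aromatic ring: the number responds to a change here, and not only to changes in the group on the saturated chain, although this step is modest and rests on a single pair. Nothing measured in the series accounts for the lower clearance seen with this fluoro.

Going by these compounds, whether the same fluoro gives a similar step when the chain carries the group of compound 1 or compound 2 remains open. Also open, on these data alone, is how chloro, methoxy or a nitrile would read at this same aromatic carbon.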